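Isobutyl to sec-butyl on a carbonyl carbon

The source may report more compounds than this note shows. Statements on the series, on what has been measured and on what is new or still open speak of the compounds shown alone.

In a functional assay on HeLa cells (Homo sapiens) for cytotoxicity, read by resazurin assay, with a stated time of 24 h (a higher number here means a weaker inhibitor, a lower number a stronger inhibitor), compound 1 (`CC(C)=CC(=O)Nc1ccn([C@H]2CC[C@H](O)[C@@H](C)O2)c(=O)n1`) gives > 64 ug/mL, which is a limit and not a number. Compound 2 (`CC(C)CC(=O)Nc1ccn([C@H]2CC[C@H](O)[C@@H](C)O2)c(=O)n1`) gives > 64 ug/mL, likewise a limit, so its position in the series has no exact reading. Compound 3 (`CC[C@H](C)C(=O)Nc1ccn([C@H]2CC[C@H](O)[C@@H](C)O2)c(=O)n1`) differs from compound 2 by sec-butyl in place of isobutyl on a carbonyl carbon. For the measured compounds named here, the only measured step bearing on this is a step that the two limits leave unreadable from compound 1 to compound 2, so it offers no size to carry over. The remaining guide is the limit of > 64 ug/mL in this assay, at which 2 of the 2 values shown sit, which covers compound 1 and compound 2 alike. No step beyond the scatter is expected in this assay, and no direction can be assigned. The expected step is a step that the limit leaves unreadable from compound 2 to compound 3. For compound 3 the estimated value is 80 ug/mL, with an expected range of 48 ug/mL to 128 ug/mL, and a further limit is the likeliest report.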

Compound 3, half-maximal inhibitory concentration: > 64 ug/mL
Compound 3 was reported as a limit; the forecaster's own chance of this, stated with the estimate: 88%; the middle value is on the limit's open side.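

For the compounds shown here, no step among compound 1, compound 2 and compound 3 can be read, as all three stand as limits: the limit of > 64 ug/mL in this assay, at which 3 of the 3 values shown sit.
The compounds shown leave open whether a readable half-maximal inhibitory concentration exists in this assay for any group on this carbonyl carbon of the shared core.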